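Benzhydrazone series: glucose-6-phosphatase inhibition notes

The compounds below may be only part of what the source reports. "The series", "measured", "known", "first", "only" and "open" are said of these compounds alone.

Measured so far:
compound 1, `COc1ccc2c(c1)CCC/C2=N\N(Cc1ccccc1)Cc1ccccc1`, > 50000 nM
compound 2, `COc1ccccc1/C=N/N(Cc1ccccc1)Cc1ccccc1`, > 100000 nM

Both values come from an assay on liver (Sus scrofa) for inhibition of glucose-6-phosphatase catalytic subunit 1 (Homo sapiens), using microsomes; a higher number here means a weaker inhibitor, a lower number a stronger inhibitor. For compound 1 the figure > 50000 nM is a limit of the assay, not a number, as recorded in the limit of > 50000 nM in this assay, at which 1 of the 2 values shown sits. For compound 2 the figure > 100000 nM is likewise a limit of the assay and not a number, as recorded in the limit of > 100000 nM in this assay, at which 1 of the 2 values shown sits. Compound 2 therefore stands at the weak end of what this assay can report; no ranking between compound 1 and compound 2 can be drawn, since both values are limits. Among the measured compounds shown here, no step between measured compounds is available.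

Compound 3, `Clc1cc(Cl)cc(/C=N/N(Cc2ccccc2)Cc2ccccc2)c1`, is not yet measured. It differs from compound 2 in one place: 3,5-dichlorophenyl in place of 2-methoxyphenyl on a carbon with a double bond to nitrogen. The rest of the molecule is unchanged.

With both measured compounds sitting at limits, no size of step can be read from the data. The expectation for compound 3 is no step beyond the scatter, a number no higher from compound 2 to compound 3 (the limit leaves the size open), and a result that again reaches only a limit. The estimate for compound 3 in this assay is 100000 nM, with a range from 30000 nM to 300000 nM.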

Compound 3, half-maximal inhibitory concentration: > 100000 nM
Compound 3: no number, only a limit; the forecaster's own chance of this, stated with the estimate: 85%; the middle value sits exactly at the limit.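

In this assay compound 3 gives > 100000 nM, a limit of the assay and not a number. Among the compounds shown here, compound 2 is also recorded only as a limit, and no step from compound 2 to compound 3 can be read. The compounds shown leave open what difference 3,5-dichlorophenyl and 2-methoxyphenyl make to inhibition, as no compound here has a numerical value.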